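Swapping a Fluorobenzothiophene for a Fluoroindole

The source may hold more compounds than are shown below. What is called first, only, known or untested is meant among the compounds shown, and "the series" means these compounds.

Measured so far:
compound 1 `NC(=O)c1ccc2c(c1)CCOC2CCN1CC=C(c2csc3cc(F)ccc23)CC1` — 186 nM
compound 2 `NC(=O)c1ccc2c(c1)CCOC2CCN1CC=C(c2c[nH]c3cc(C(F)(F)F)ccc23)CC1` — > 1000 nM
compound 3 `NC(=O)c1ccc2c(c1)CCOC2CCN1CC=C(c2c[nH]c3c(Cl)c(Cl)ccc23)CC1` — > 1000 nM

Within the data shown here, in an assay on cells for binding affinity to 5-hydroxytryptamine receptor 1B (Homo sapiens), read by radioligand binding (a lower number here means a stronger inhibitor, a higher number a weaker inhibitor), compound 1 gives 186 nM, the only true number among the three. For compound 2 the value > 1000 nM is a limit of the assay rather than a number. For compound 3 the value > 1000 nM is likewise a limit. Both of these indole-bearing compounds sit at the limit of > 1000 nM in this assay, at which 2 of the 3 values shown sit. Compound 4 `NC(=O)c1ccc2c(c1)CCOC2CCN1CC=C(c2c[nH]c3ccc(F)cc23)CC1` has not yet been measured; it differs from compound 1 by 5-fluoro-1H-indol-3-yl in place of 6-fluoro-1-benzothiophen-3-yl on a double-bonded ring carbon. Among the measured compounds shown here, no pair of measured compounds differs in just one place, so the size of this step has to be guessed. A loss beyond the usual scatter is expected, with compound 4 estimated at 600 nM (range 150 nM to 3000 nM), meaning an expected step of a 3.2-fold higher number from compound 1 to compound 4 (0.51 log units; beyond the scatter).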

Compound 4, inhibition constant: > 1000 nM
Compound 4 gave a limit, no number (the forecaster's own chance of this, stated with the estimate: 40%); middle value at least 1.6-fold (0.22 log units) from the limit.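

For compound 4 the value > 1000 nM is a limit of the assay, not a number. In this assay, among these compounds, this still gives the first step that can be read at this position, an at least 5.3-fold higher number from compound 1 to compound 4 (0.73 log units; beyond the scatter): putting 5-fluoro-1H-indol-3-yl in place of 6-fluoro-1-benzothiophen-3-yl costs affinity beyond the scatter, and the true loss may be larger. Most values shown now rest at one ceiling: the limit of > 1000 nM in this assay, at which 3 of the 4 values shown sit.

As far as these compounds go, the swap changes both the ring hetero atom and the place of the fluorine, and which of these matters stays open. A 6-fluoro-1H-indol-3-yl or 5-fluoro-1-benzothiophen-3-yl group on the same carbon would separate the two.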